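The compounds below may be only part of what the source reports. "The series", "measured", "known", "first", "only" and "open" are said of these compounds alone.

Compound 1 `NS(=O)(=O)c1cc(-c2nnc(CN3CCN(c4ccccc4)CC3)o2)c(Cl)cc1SCc1ccccc1`, a functional assay on HCT-116 cells (Homo sapiens) for cytotoxicity, read by MTT assay, with a stated time of 72 h; a higher number here means a weaker inhibitor, a lower number a stronger inhibitor: 105000 nM
Compound 2 `Cc1ccc(C)c(N2CCN(Cc3nnc(-c4cc(S(N)(=O)=O)c(SCc5ccccc5)cc4Cl)o3)CC2)c1`, this assay: 17000 nM
Compound 3 `CCOC(=O)c1cn(Cc2nnc(-c3cc(S(N)(=O)=O)c(SCc4ccccc4)cc3Cl)o2)nn1`, this assay: 108000 nM

Compound 3 has the highest number of the three, but compound 1 sits within the usual scatter of it, so the two cannot be told apart; only compound 2 lies clearly lower. Compound 4 `NS(=O)(=O)c1cc(-c2nnc(Cn3cc(-c4ccccc4)nn3)o2)c(Cl)cc1SCc1ccccc1` differs from compound 3 by phenyl in place of ethoxycarbonyl on an aromatic carbon. Within the data shown here, no measured pair tests this exact swap. The step of a 1.0-fold higher number from compound 1 to compound 3 (0.01 log units; within the scatter) shows that exchanging the whole group at this position changed little, while a 6.2-fold lower number from compound 1 to compound 2 (0.79 log units; beyond the scatter) shows that adding to an aromatic ring at the far end gave a modest gain. On that thin basis a small lowering, perhaps not beyond the scatter, is expected: a 1.8-fold lower number from compound 3 to compound 4 (0.26 log units; within the scatter). Compound 4 is therefore estimated at 60000 nM, with a range from 20000 nM to 150000 nM.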

Compound 4, half-maximal inhibitory concentration: 75000 nM
Estimate against measurement, compound 4: 1.3-fold (0.10 log units) below, and the stated range covers the measured number.
By their numbers in this assay, from the lowest: compound 2; then compounds 4, 1 and 3 (each within the scatter of the next).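

In this assay phenyl in place of ethoxycarbonyl gives a 1.4-fold lower number from compound 3 to compound 4 (0.16 log units; within the scatter) and so does not separate an all-carbon ring from an ester on this aromatic carbon. Keeping phenyl at the far end while exchanging the linking group gives a 1.4-fold lower number from compound 1 to compound 4 (0.15 log units; within the scatter) and so does not separate 4-phenyl-1H-1,2,3-triazol-1-yl from 4-phenylpiperazin-1-yl either. Nothing available explains these results. On these data alone, whether an amine or a carboxylic acid on this carbon would shift the number remains open. So does whether the two methyl groups of compound 2 would lower the number on the phenyl of compound 4.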